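The source may hold more compounds than are shown below. What is called first, only, known or untested is meant among the compounds shown, and "the series" means these compounds.

Measured so far in a functional assay on RAW264.7 cells (Mus musculus) for inhibition, read by Griess assay, with stated times of 2 h and 24 h; a higher number here means a weaker inhibitor, a lower number a stronger inhibitor:
compound 1 `COc1ccc([C@@H]2C/C(=N\O)c3c(O)cc(OCc4cn(CC5CC5)nn4)cc3O2)cc1O`: 6320 nM
compound 2 `COc1ccc([C@@H]2CC(=O)c3c(O)cc(OCc4cn(Cc5ccc(Cl)cc5)nn4)cc3O2)cc1O`: 17800 nM

Compound 1 holds the lowest of the two numbers in this assay; compound 2 sits at a higher number, and the gap between the two lies beyond the usual scatter. Among the compounds with values here, no pair of these two differs in a single place, so no single step can be read from them.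

The unmeasured compound 3 `COc1ccc([C@@H]2C/C(=N\O)c3c(O)cc(OCc4cn(Cc5ccccc5C)nn4)cc3O2)cc1O` is reached from compound 1 by one change: 2-methylphenyl in place of cyclopropyl on a saturated chain carbon bound to an aromatic nitrogen. Within the data shown here, nothing among the measured compounds isolates this change, so its effect in this assay is unknown. The step from compound 1 to compound 3 is expected to be small, a 1.1-fold higher number from compound 1 to compound 3 (0.04 log units; within the scatter), with no direction that can be read from the two numbers shown. For compound 3 the expected value in this assay is 7000 nM, within a range from 2500 nM to 20000 nM.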

Compound 3, half-maximal inhibitory concentration: 18000 nM
For compound 3 the middle estimate is 2.6-fold (0.41 log units) below the measured one; measured number inside the range.
By their numbers in this assay, from the lowest: compound 1; then compounds 2 and 3 (each within the scatter of the next).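

In this assay, the first step read in the series shows that this position, on a saturated chain carbon bound to an aromatic nitrogen, responds to the group it carries: 2-methylphenyl in place of cyclopropyl gives a 2.8-fold higher number from compound 1 to compound 3 (0.45 log units; beyond the scatter). Of these two groups on the core of compound 1, cyclopropyl gives the stronger inhibitor, so the position does not treat all groups alike. No measured evidence bears on the reason for this step.

This single change leaves open whether the ring type or the methyl group carries the step, a question that plain phenyl or cyclohexyl at this position would address. Compound 2 differs from compound 1 and compound 3 in more than one place, and its steps to them cannot be read.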